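This account rests on a few compounds, and the source may have more. Where it says the series, first, only, none or still open, it means among the compounds named here.

Working notes on the series. The common core carries a 2,4-dichlorophenoxymethyl group on a fused bicyclic lactam joined through an amide-linked thioether to a nitrile-bearing pyrimidinone or pyrimidine; the two cores are compared only as wholes here, and the difference between the core of compound 1 and the core of compound 3 is not broken down.

Compound 1 `Cn1c(SCC(=O)Nn2c(COc3ccc(Cl)cc3Cl)nc3ccccc3c2=O)nc(-c2ccc(Cl)cc2)c(C#N)c1=O` gives 80.8% in a functional assay on the whole organism (strain albino) for inhibition, with Rattus norvegicus as the target, read by paw edema, with stated times of 1 h and 0.5 h, at a dose of 100 mg/kg by the oral route; on this read-out higher numbers stand for more inhibition at the one dose given (going by the name of the read-out) and lower numbers for less inhibition. Compound 2 `Cn1c(SCC(=O)Nn2c(COc3ccc(Cl)cc3Cl)nc3ccccc3c2=O)nc(-c2ccc(O)cc2)c(C#N)c1=O` gives 76.9% in this assay. The change between them, (hydroxy in place of chloro on an aromatic carbon), made a step of a number 3.9 percentage points lower from compound 1 to compound 2 (within the scatter).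

Compound 3 `N#Cc1c(Nc2ccc(Cl)cc2)nc(SCC(=O)Nn2c(COc3ccc(Cl)cc3Cl)nc3ccccc3c2=O)nc1-c1ccccc1` gives 51.9% in this assay, the lowest of the three measured numbers, beyond the scatter below compound 2 and compound 1.

Compound 4 `N#Cc1c(Nc2ccc(O)cc2)nc(SCC(=O)Nn2c(COc3ccc(Cl)cc3Cl)nc3ccccc3c2=O)nc1-c1ccccc1` is not yet measured. It differs from compound 3 by hydroxy in place of chloro on an aromatic carbon, the same change as that from compound 1 to compound 2, here on the ring carried as the (4-chlorophenyl)amino group. Because a number 3.9 percentage points lower from compound 1 to compound 2 (within the scatter) stayed within the scatter, the step to compound 4 is expected to be a number 3.9 percentage points lower from compound 3 to compound 4 (within the scatter). Compound 4 is therefore estimated at 48%, between 35% and 62%.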

Compound 4, a percentage reported as inhibition, in the whole organism at one dose (the size of the read-out at that dose, not a potency): 61.5%
Beside the measured number, compound 4's estimate is 13.5 percentage points below it; measured number inside the range.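

In this assay the change of chloro to hydroxy gives a step of a number 9.6 percentage points higher from compound 3 to compound 4 (within the scatter), and set beside the earlier step it does not differ from it: the same change on two cores in this assay, a number 3.9 percentage points lower (within the scatter) from compound 1 to compound 2 and a number 9.6 percentage points higher (within the scatter) from compound 3 to compound 4, 13.5 percentage points apart, within the scatter of two such steps. Within these two pairs the change therefore carries from one core to the other without a step beyond the scatter, whether it is made on the 4-chlorophenyl group of compound 1 or on the (4-chlorophenyl)amino group of compound 3. This does not show that the change has no effect on either core, nor does it give any meaning to the opposite directions of the two steps, and two pairs at one dose in one read-out support no rule for other cores in the series.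

The compounds shown leave open whether other groups at the same place on the aromatic ring, such as an amine, a methoxy group or a carboxylic acid, would also stay within the scatter on both cores. Only chloro and hydroxy can be compared there, and each on only these two cores.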